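The source may hold more compounds than are shown below. What is called first, only, known or untested is meant among the compounds shown, and "the series" means these compounds.

Measured so far:
- Compound 1 `OCc1cc2c(s1)CCC(NCCCc1ccccc1)CC2` gives 30 nM in an assay on membranes from liver for displacement of a labelled ligand from Sigma intracellular receptor 2 (Rattus norvegicus), read by scintillation counting, with a stated time of 120 min, in the presence of a further agent that is not named here; on this read-out lower numbers stand for stronger inhibition and higher numbers for weaker inhibition.
- Compound 2 `OCc1cc2c(s1)CCC(NCCCCc1ccccc1)CC2` gives 73 nM in this assay.

Only these two compounds have been measured. Among the measured compounds shown here, compound 2 stands at the higher of the two numbers, which on this read-out means the weaker binding; the single measured step, a 2.4-fold higher number from compound 1 to compound 2 (0.39 log units; beyond the scatter), lies beyond the usual scatter and concerns only the length of the chain that links the amine nitrogen to the phenyl group.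

Compound 3 `Brc1cc2c(s1)CCC(NCCCCc1ccccc1)CC2` keeps the chain of compound 2 unchanged and differs from it only at the fused core: bromo in place of hydroxymethyl on an aromatic carbon. For the measured compounds named here, no measured step touches this position, so the step from compound 1 to compound 2 cannot be used to predict the outcome. With nothing to compare against, the most cautious expectation is a number close to that of compound 2, with wide uncertainty in both directions. On that basis compound 3 is expected to show 50 nM in this assay, within a range from 10 nM to 250 nM. The step from compound 2 to compound 3 is thus expected to be a 1.5-fold lower number from compound 2 to compound 3 (0.16 log units; within the scatter).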

Compound 3, inhibition constant: 13 nM
The estimate for compound 3 lay 3.8-fold (0.59 log units) above the measured number; the range from low to high includes it.
By their numbers in this assay, from the lowest: compound 3; then compound 1; then compound 2.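

In this assay, putting bromo in place of hydroxymethyl on the aromatic carbon next to the ring sulfur gives a 5.6-fold lower number from compound 2 to compound 3 (0.75 log units; beyond the scatter), with the chain left unchanged. Among the compounds shown here, the earlier step concerned only the chain, so this is the first sign that the number also responds to a change at this position on the core. The hydroxymethyl group, with its hydrogen-bond donor and acceptor, is also not needed for a low number here, since bromo has neither and gives the lower number, although nothing shown explains why the number falls.

A single swap removes one group and adds another, so it cannot separate the loss of hydroxymethyl from the arrival of bromo; a plain hydrogen, chloro, methyl or an amine at the same carbon would help to tell these apart. On these data alone, it also remains open whether bromo would lower the number to a similar extent on the shorter chain of compound 1, or whether this step holds only with the chain of compound 2.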